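This account rests on a few compounds, and the source may have more. Where it says the series, first, only, none or still open, it means among the compounds named here.

In an ADME assay on the whole organism (plasma, strain 129/SvEvBrd x C57BL/6) for pharmacokinetics, with Mus musculus as the target, at a dose of 10 mg/kg by the oral route (on this read-out higher numbers stand for higher exposure at the dose given and lower numbers for lower exposure), three compounds that differ only in one group on the shared core have been measured. Compound 1 `CC(F)(F)c1nc([C@@H](O)[C@H](O)[C@H](O)CO)c[nH]1` gives 1190 ng.h/mL, compound 2 `Cc1nc(-c2nc([C@@H](O)[C@H](O)[C@H](O)CO)c[nH]2)cs1` gives 1970 ng.h/mL, and compound 3 `OC[C@@H](O)[C@@H](O)[C@H](O)c1c[nH]c(-c2cocn2)n1` gives 868 ng.h/mL. Compound 3 stands close to compound 1, with a 1.4-fold lower number from compound 1 to compound 3 (0.14 log units; within the scatter), and apart from compound 2, with a 2.3-fold lower number from compound 2 to compound 3 (0.36 log units; beyond the scatter).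

Compound 4 `OC[C@@H](O)[C@@H](O)[C@H](O)c1c[nH]c(-c2ncccn2)n1` brings one further change at the same place, pyrimidin-2-yl in place of 1,3-oxazol-4-yl on an aromatic carbon. All three measured steps bear on it, since each exchanges the group at this place. Besides the two above, there is a 1.7-fold higher number from compound 1 to compound 2 (0.22 log units; within the scatter). The largest of them is modest, and none involves pyrimidin-2-yl, so the data give no sign of a large shift. The expected result in this assay is therefore no change beyond the scatter, in either direction, with an estimated 1.2-fold higher number from compound 3 to compound 4 (0.06 log units; within the scatter). The estimated value for compound 4 is 1000 ng.h/mL, with an expected range from 450 ng.h/mL to 2200 ng.h/mL.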

Compound 4, area under the concentration-time curve: 799 ng.h/mL
The estimate for compound 4 lay 1.3-fold (0.10 log units) above the measured number; the measured number falls inside the stated range.
By their numbers in this assay, from the lowest: compounds 4, 3, 1 and 2 (each within the scatter of the next, the first and the last beyond it).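

In this assay, pyrimidin-2-yl, with its six-membered aromatic ring, takes the place of the five-membered 1,3-oxazol-4-yl on this aromatic carbon between two ring nitrogen atoms with no change beyond the scatter (a 1.1-fold lower number from compound 3 to compound 4 (0.04 log units; within the scatter)), and the same holds against 1,1-difluoroethyl (a 1.5-fold lower number from compound 1 to compound 4 (0.17 log units; within the scatter)). Against 2-methyl-1,3-thiazol-4-yl the step is modest but beyond the scatter (a 2.5-fold lower number from compound 2 to compound 4 (0.39 log units; beyond the scatter)), so compound 2 now stands apart from both compound 3 and compound 4, while compound 1 lies within the scatter of all three. Nothing measured here accounts for these numbers.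

From the compounds shown here alone, it remains open whether a 1,3-thiazol-4-yl ring without the methyl group would stay with compound 2 or fall with compound 3 and compound 4. Going by these compounds, it is also open whether an amine or a carboxylic acid on this carbon would move the exposure outside the span seen so far.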